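The source may report more compounds than this note shows. Statements on the series, on what has been measured and on what is new or still open speak of the compounds shown alone.

Compound 2, `COc1ccc(-c2ccc([C@@H](c3ccccc3)[C@@](O)(CCN(C)C)c3cccc4ccccc34)c(OC)n2)cc1`, and compound 1, `COc1nc(C2CCCCC2)ccc1[C@@H](c1ccccc1)[C@@](O)(CCN(C)C)c1cccc2ccccc12`, share one core and differ at a single aromatic carbon, where compound 2 carries a 4-methoxyphenyl in place of the cyclohexyl of compound 1. In a toxicity assay on HeLa cells (Homo sapiens) for cytotoxicity (on this read-out lower numbers stand for higher toxicity in this test and higher numbers for lower toxicity in this test), compound 1 gives 57.7 ug/mL. For compound 2 this assay reports only a limit, > 64 ug/mL. Compound 2 thus stands at the limit of > 64 ug/mL in this assay, at which 1 of the 2 values shown sits. Going by the values given here, the one measured step, an at least 1.1-fold higher number from compound 1 to compound 2 (0.04 log units; that floor lies within the scatter), shows nothing beyond the scatter. Compound 3, `COc1nc(-c2ccc(C(F)(F)F)cc2)ccc1[C@@H](c1ccccc1)[C@@](O)(CCN(C)C)c1cccc2ccccc12`, differs from compound 2 by trifluoromethyl in place of methoxy on an aromatic carbon. Among the compounds with values here, no measured step covers a change of this kind; the only step recorded, cyclohexyl to 4-methoxyphenyl, was small, so for this assay a step of no size beyond the scatter is expected, an at least 1.1-fold lower number from compound 2 to compound 3 (0.06 log units; that floor lies within the scatter). Compound 3 is accordingly estimated at 55 ug/mL in this assay, within a range from 25 ug/mL to 64 ug/mL, with a fair chance that again only a limit is reported.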

Compound 3, half-maximal cytotoxic concentration: > 64 ug/mL
Compound 3 gave a limit, no number; the forecaster's own chance of this, stated with the estimate: 45%; middle value at least 1.1-fold (0.06 log units) away from the limit.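

In this assay compound 3 also gives only a limit, > 64 ug/mL, so with 4-(trifluoromethyl)phenyl at this place the read-out stays where it stood with 4-methoxyphenyl: the limit of > 64 ug/mL in this assay, at which 2 of the 3 values shown sit.

Putting 4-(trifluoromethyl)phenyl in place of cyclohexyl gives an at least 1.1-fold higher number from compound 1 to compound 3 (0.04 log units; that floor lies within the scatter), so this second exchange of cyclohexyl, like the first, shows nothing beyond the scatter. Compound 2 and compound 3 both stand as limits, and the step between them cannot be read.

The compounds shown leave open whether a phenyl group carrying an amine or a carboxylic acid in place of trifluoromethyl would give a number rather than a limit in this assay. They also leave open how far compound 2 and compound 3 lie beyond the limit they share.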